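Sulfoxide in place of the thioether on the shared core

The source may report more compounds than this note shows. Statements on the series, on what has been measured and on what is new or still open speak of the compounds shown alone.

Measured so far:
compound 1 `CCCn1c(=O)c2[nH]c(-c3ccccc3)nc2n(CCSCC)c1=O`: 117 nM
compound 2 `CCSCCn1c(=O)n(CC)c(=O)c2[nH]c(-c3ccccc3)nc21`: 407 nM
compound 3 `CCCn1c(=O)c2c(nc(-c3ccccc3)n2C)n(CC2CCCO2)c1=O`: 631 nM

In an assay on HeLa cells for displacement of a labelled ligand from adenosine receptor A3 (Homo sapiens), read by scintillation counting (a higher number here means a weaker inhibitor, a lower number a stronger inhibitor), compound 1 gives 117 nM, the lowest of the three numbers measured. Compound 2 gives 407 nM; the step of a 3.5-fold higher number from compound 1 to compound 2 (0.54 log units; beyond the scatter) is a change of hydrogen in place of methyl on a saturated chain carbon, two bonds along the chain from an aromatic nitrogen. Compound 3 gives 631 nM; it differs from compound 1 in more than one place, so its value is noted without a single step being assigned to it.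

Compound 4 `CCCn1c(=O)c2[nH]c(-c3ccccc3)nc2n(CC[S+]([O-])CC)c1=O` is not yet measured. Its change from compound 1 is a group of 4 heavy atoms (2 carbon, 1 oxygen, 1 sulfur; no ring) in place of a group of 3 heavy atoms (2 carbon, 1 sulfur; no ring), on a saturated chain carbon, two bonds along the chain from an aromatic nitrogen. Within the data shown here, no measured step in this assay addresses a change of this kind: the one single-point step, from compound 1 to compound 2, concerns the chain on the other side of the core, and it was modest. The expectation for this assay therefore rests on the general size of the steps seen, not on a direct precedent, and a modest weakening or no change beyond the scatter is expected.

Compound 4 is estimated at 250 nM, with a range of 80 nM to 800 nM, which corresponds to an expected step of a 2.1-fold higher number from compound 1 to compound 4 (0.33 log units; beyond the scatter).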

Compound 4, inhibition constant: 245 nM
The estimate for compound 4 lay 1.0-fold (0.01 log units) above the measured number; the range from low to high includes it.
By their numbers in this assay, from the lowest: compound 1; then compounds 4, 2 and 3 (each within the scatter of the next, the first and the last beyond it).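

In this assay, among these compounds, the step of a 2.1-fold higher number from compound 1 to compound 4 (0.32 log units; beyond the scatter) gives the first reading for a change in the ethylsulfanyl group itself, whereas the earlier single-place step of a 3.5-fold higher number from compound 1 to compound 2 (0.54 log units; beyond the scatter) concerned hydrogen in place of methyl. It shows that the ethylsulfanyl group, on a saturated chain carbon, two bonds along the chain from an aromatic nitrogen, can take an added oxygen on the sulfur at a modest cost: the loss lies beyond the scatter, but the sulfoxide still gives a measurable inhibition constant. Nothing available bears on why the number moves as it does.

This is a single step at this position, so it sets no trend for the chain, and it cannot show whether the sulfur or the added oxygen governs the result. A sulfone, with a second oxygen on the same sulfur, would extend the same change, while an ethoxy group or a longer alkyl chain in place of ethylsulfanyl would test whether the sulfur is needed at all.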